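The source may report more compounds than this note shows. Statements on the series, on what has been measured and on what is new or still open speak of the compounds shown alone.

In a functional assay on HeLa cells (Homo sapiens) for inhibition, read by thymidine incorporation, with a stated time of 3 h (a higher number here means a weaker inhibitor, a lower number a stronger inhibitor), compound 1 `CCCCc1ccc(Nc2nc(Cl)c3ncn([C@@H]4C[C@@H](O)[C@H](CO)O4)c3n2)cc1` gives 11000 nM, the highest number of the three measured compounds and so the weakest inhibitor among them. Compound 2 `CCCCc1ccc(Nc2nc(N)c3ncn([C@@H]4C[C@@H](O)[C@H](CO)O4)c3n2)cc1` gives 1000 nM, and compound 3 `CCCCc1ccc(Nc2ncc3ncn([C@@H]4C[C@@H](O)[C@H](CO)O4)c3n2)cc1` gives 4800 nM.

Compound 4 `CCCCc1ccc(Nc2nc(Cl)c3ncn(COCCO)c3n2)cc1` keeps the chloro group of compound 1 and differs on an aromatic nitrogen: (2-hydroxyethoxy)methyl in place of 4-hydroxy-5-(hydroxymethyl)oxolan-2-yl on an aromatic nitrogen. Among the compounds with values here, no measured step touches that nitrogen. All three change a group on an aromatic carbon instead. Amino in place of chloro gives an 11-fold lower number from compound 1 to compound 2 (1.04 log units; beyond the scatter), a large step. Hydrogen in place of chloro gives a 2.3-fold lower number from compound 1 to compound 3 (0.36 log units; beyond the scatter), and hydrogen in place of amino gives a 4.8-fold higher number from compound 2 to compound 3 (0.68 log units; beyond the scatter), both modest.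

These steps bear on the new change only indirectly, showing that one swap can move the number in this assay well beyond the scatter. They give no direction for it, so a modest step to a higher number is a tentative expectation with wide margins. Compound 4 is estimated at 20000 nM, with an expected range of 6000 nM to 60000 nM. This estimate means a 1.8-fold higher number from compound 1 to compound 4 (0.26 log units; within the scatter).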

Compound 4, half-maximal inhibitory concentration: 9000 nM
Compound 4: the middle estimate sits 2.2-fold (0.35 log units) above what was measured; measured number inside the range.
By their numbers in this assay, from the lowest: compound 2; then compounds 3, 4 and 1 (each within the scatter of the next, the first and the last beyond it).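

In this assay, putting the open chain (2-hydroxyethoxy)methyl in place of the ring group 4-hydroxy-5-(hydroxymethyl)oxolan-2-yl on the aromatic nitrogen gives a 1.2-fold lower number from compound 1 to compound 4 (0.09 log units; within the scatter), so the two compounds cannot be told apart here. Unlike the earlier steps, which all changed a group on an aromatic carbon, this one shows that, with chloro on the shared core, the five-membered non-aromatic ring and its defined stereocentres can be given up with no loss beyond the scatter. Nothing available explains why the number holds at this nitrogen.

Within the data shown here, whether the same swap would hold with the amino group of compound 2 remains open, since the change at this nitrogen is seen only with chloro. Also open, from the compounds shown here alone, is how a longer chain, or a chain ending in an amine or a carboxylic acid, would behave on this nitrogen.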